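The source may hold more compounds than are shown below. What is called first, only, known or untested is meant among the compounds shown, and "the series" means these compounds.

Among the measured compounds shown here, in a functional assay on MCF7 cells (Homo sapiens) for cytotoxicity, read by MTT assay, with a stated time of 72 h (a higher number here means a weaker inhibitor, a lower number a stronger inhibitor), compound 2 `Cc1cc(-c2ccccc2)n(/C(N)=N/S(=O)(=O)c2cc(C)c(Cl)cc2SCc2ccc(C(F)(F)F)cc2)n1` gives 16000 nM, the lower of the two values measured so far; compound 1 `Cc1cc(S(=O)(=O)/N=C(\N)n2nccc2-c2ccccc2)c(SCc2cccc(Cl)c2)cc1Cl` gives 88000 nM, and that gap lies beyond the usual scatter. Compound 3 `Cc1cc(S(=O)(=O)/N=C(\N)n2nccc2-c2ccccc2)c(SCc2ccc(C(F)(F)F)cc2)cc1Cl` has not yet been measured. It differs from compound 2 in a single place: hydrogen in place of methyl on an aromatic carbon. For the measured compounds named here, no measured pair shows what this change does. The step is expected to be small, a 1.6-fold higher number from compound 2 to compound 3 (0.19 log units; within the scatter), with a modest loss of potency if anything. For compound 3 the expected value is 25000 nM, likely between 8000 nM and 80000 nM.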

Compound 3, half-maximal inhibitory concentration: 25000 nM
The estimate for compound 3 equals the measured number at the digits printed, and the stated range covers the measured number.
By their numbers in this assay, from the lowest: compounds 2 and 3 (each within the scatter of the next); then compound 1.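

In this assay, replacing 3-methyl-5-phenyl-1H-pyrazol-1-yl with 5-phenyl-1H-pyrazol-1-yl gives a 1.6-fold higher number from compound 2 to compound 3 (0.19 log units; within the scatter) and so makes no clear difference, which means this methyl is not needed to keep the activity seen here. Among the compounds shown here, with no methyl in either compound, the change on the saturated chain carbon bound to a sulfur gives a 3.5-fold lower number from compound 1 to compound 3 (0.55 log units; beyond the scatter) in favour of 4-(trifluoromethyl)phenyl over 3-chlorophenyl. Nothing available explains either step. Going by these compounds, what an amine, a carboxylic acid or a longer chain such as propyl would do on this ring carbon remains open.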